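Cyclopropyl to isopropyl: working notes on compound 4

This account rests on a few compounds, and the source may have more. Where it says the series, first, only, none or still open, it means among the compounds named here.

Within the data shown here, in a functional assay on A-375 cells (Homo sapiens) for antiproliferative activity, read by MTT assay, with a stated time of 72 h (on this read-out lower numbers stand for stronger inhibition and higher numbers for weaker inhibition), compound 3 (`COc1ncc(-c2ccc3c(c2)N(C2CC2)C(=O)CO3)cc1NS(=O)(=O)c1ccc(F)cc1`) gives 23900 nM as the only actual number of the series. Compound 1 (`COc1cccc(N2C(=O)COc3ccc(-c4cnc(OC)c(NS(=O)(=O)c5ccc(F)cc5)c4)cc32)c1`) reads > 40000 nM and this is a limit of the assay, not a number. Compound 2 (`COc1ncc(-c2ccc3c(c2)N(C2CCCCC2)C(=O)CO3)cc1NS(=O)(=O)c1ccc(F)cc1`) reads > 40000 nM and this too is a limit. The steps among these compounds are therefore bounded by the limit of > 40000 nM in this assay, at which 2 of the 3 values shown sit, and not by pairs of numbers.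

Compound 4 (`COc1ncc(-c2ccc3c(c2)N(C(C)C)C(=O)CO3)cc1NS(=O)(=O)c1ccc(F)cc1`) differs from compound 3 in one place: isopropyl in place of cyclopropyl on an amide-type nitrogen in a ring with isopropyl in place of cyclopropyl on an amide-type nitrogen in a ring.

The measured steps bearing on this change touch the same nitrogen: an at least 1.6-fold lower number from compound 2 to compound 3 (0.22 log units; that floor lies within the scatter) for cyclopropyl in place of cyclohexyl and an at least 1.6-fold lower number from compound 1 to compound 3 (0.22 log units; that floor lies within the scatter) for cyclopropyl in place of 3-methoxyphenyl. Both give floors only. The third is a step that the two limits leave unreadable from compound 1 to compound 2 and adds no size. None of them covers an exchange of cyclopropyl for isopropyl.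

Among the measured compounds shown here, with compound 3 as the anchor at 23900 nM and no step of known size for this exchange, no step beyond the scatter is expected in this assay. A reading at the limit of the assay remains possible for compound 4. The expected change is a 1.1-fold higher number from compound 3 to compound 4 (0.04 log units; within the scatter) and this is only an estimate. For compound 4 the estimated value is 26000 nM with an expected range from 11000 nM to 40000 nM in this assay as the measure.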

Compound 4, half-maximal inhibitory concentration: 9950 nM
Compound 4: the middle estimate sits 2.6-fold (0.42 log units) above what was measured; the whole stated range lies above it.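

At the amide-type nitrogen, this assay now gives a step with actual numbers at both ends and beyond the scatter: a 2.4-fold lower number from compound 3 to compound 4 (0.38 log units; beyond the scatter). Cyclopropyl and isopropyl have the same count of heavy atoms and differ in the three-membered ring, so the presence or absence of that ring alone separates these two compounds. The steps against the other two groups also pass the scatter, unlike the earlier floors to compound 3, with an at least 4.0-fold lower number from compound 2 to compound 4 (0.60 log units; beyond the scatter) for the exchange of cyclohexyl and an at least 4.0-fold lower number from compound 1 to compound 4 (0.60 log units; beyond the scatter) for the exchange of 3-methoxyphenyl, but compound 1 and compound 2 each read as a limit of the assay and not a number, and both steps are floors only: the limit of > 40000 nM in this assay, at which 2 of the 4 values shown sit.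

Among these compounds, with only two actual numbers at this nitrogen, no trend across its groups can be stated. Going by these compounds, how methyl, ethyl, tert-butyl or a chain ending in an amine would read at this position remains open, as does the true size of the steps from the cyclohexyl and 3-methoxyphenyl compounds.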